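Compound 1 to compound 4: removing the benzyl group

The compounds below may be only part of what the source reports. "The series", "measured", "known", "first", "only" and "open" are said of these compounds alone.

Measured in a functional assay on CCRF-CEM cells (Homo sapiens) for cytotoxicity, in the absence of a further agent; a lower number here means a stronger inhibitor, a higher number a weaker inhibitor:
- compound 1 `COC(=O)c1ccc(CN(CCCc2c(N)nc(N)nc2O)c2cc(F)cc(F)c2[N+](=O)[O-])cc1`: > 100000 nM (a limit)
- compound 2 `COC(=O)c1ccc(CN(CCCc2c(N)nc(N)nc2O)c2cc(F)c([N+](=O)[O-])cc2[N+](=O)[O-])cc1`: 3900 nM
- compound 3 `COC(=O)c1ccc(CN(CCCc2c(N)nc(N)nc2O)c2cc(F)c(F)cc2[N+](=O)[O-])cc1`: 55000 nM

Compound 1 gives > 100000 nM in this assay, which is a limit and not a number. This is the limit of > 100000 nM in this assay, at which 1 of the 3 values shown sits.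

Compound 4 `Nc1nc(N)c(CCCNc2cc(F)cc(F)c2[N+](=O)[O-])c(O)n1` has hydrogen in place of 4-(methoxycarbonyl)benzyl on a nitrogen on an aromatic ring.

Two measured steps are available. One is large, a 14-fold higher number from compound 2 to compound 3 (1.15 log units; beyond the scatter), and the other is an at least 1.8-fold lower number from compound 1 to compound 3 (0.25 log units; that floor lies within the scatter). Both concern the groups on the nitrophenyl ring, and neither removes the 4-(methoxycarbonyl)benzyl, so neither gives a size for this change. As far as these compounds go, with only a limit as the starting point, no step beyond the scatter is expected in this assay, and the direction stays open.

For compound 4, the expected value is 80000 nM, with an estimated range of 20000 nM to 300000 nM. This estimate means an expected at least 1.2-fold lower number from compound 1 to compound 4 (0.09 log units; that floor lies within the scatter).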

Compound 4, half-maximal inhibitory concentration: 97000 nM
For compound 4 the middle estimate is 1.2-fold (0.08 log units) below the measured one; low and high end bracket the measured number.
By their numbers in this assay, from the lowest: compound 2; then compounds 3 and 4 (each within the scatter of the next). At a limit, above all of these: compound 1.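

Hydrogen in place of 4-(methoxycarbonyl)benzyl on this nitrogen gives an at least 1.0-fold lower number from compound 1 to compound 4 (0.01 log units; that floor lies within the scatter) in this assay. Compound 1 gives > 100000 nM, which is a limit and not a number, so the true size and direction of this step stay unread: the limit of > 100000 nM in this assay, at which 1 of the 4 values shown sits.

Compound 4 gives 97000 nM, the only number shown for the 3,5-difluoro-2-nitrophenyl group in this series.

Open, as far as these compounds go, is whether a carboxylic acid in place of the methyl ester, or a plain benzyl, on this nitrogen would shift the number. Also open, from the compounds shown here alone, is whether hydrogen on the nitrogen would read the same with the 4,5-difluoro-2-nitrophenyl group of compound 3, where the starting value is a number and not a limit.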